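Ethoxy in place of methyl on the benzylic carbon

The compounds below may be only part of what the source reports. "The series", "measured", "known", "first", "only" and "open" are said of these compounds alone.

Measured compounds:
compound 1, `Cc1cccc(C)c1-c1cccc(COc2ccc(CC(C)C(=O)O)cn2)c1` — 65 nM
compound 2, `COC(Cc1ccc(OCc2cccc(-c3c(C)cccc3C)c2)nc1)C(=O)O` — 120 nM
compound 3, `Cc1cccc(C)c1-c1cccc(COc2ccc(C(C)CC(=O)O)cn2)c1` — 10 nM

The three compounds share one core and differ only in the acid-bearing side chain. In a functional assay on CHO cells for agonist activity at Free fatty acid receptor 1 (Homo sapiens), read by calcium flux (a higher number here means that more compound is needed for the effect, a lower number that less compound is needed), compound 3 gives the lowest number of the three: it stands a 6.5-fold lower number from compound 1 to compound 3 (0.81 log units; beyond the scatter) and a 12-fold lower number from compound 2 to compound 3 (1.08 log units; beyond the scatter), both beyond the scatter.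

Compound 4, `CCOC(CC(=O)O)c1ccc(OCc2cccc(-c3c(C)cccc3C)c2)nc1`, is the next step from compound 3. The change is ethoxy in place of methyl on a saturated chain carbon bound to an aromatic carbon and a saturated chain carbon. For the measured compounds named here, one measured step bears on it, though at a different position of the chain: an alkoxy group entering in place of methyl on the carbon bound to the carbonyl, which gave a 1.8-fold higher number from compound 1 to compound 2 (0.27 log units; within the scatter), a step within the scatter. Going by the values given here, the present change puts a longer alkoxy group on the carbon bound to the aromatic carbon instead, so that earlier step is only a loose guide; no measured pair shows an alkoxy group at this position.

Among the compounds with values here, since the one comparable alkoxy-for-methyl step from compound 1 to compound 2 stayed within the scatter, compound 4 is expected to change little, a 1.5-fold higher number from compound 3 to compound 4 (0.18 log units; within the scatter), with the wider range reflecting the different position. The estimate for compound 4 in this assay is 15 nM, between 4 nM and 60 nM.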

Compound 4, half-maximal effective concentration in the Free fatty acid receptor 1 assay: 14 nM
The estimate for compound 4 lay 1.1-fold (0.03 log units) above the measured number, and the stated range covers the measured number.
By their numbers in the Free fatty acid receptor 1 assay, from the lowest: compounds 3 and 4 (each within the scatter of the next); then compounds 1 and 2 (each within the scatter of the next).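

In the Free fatty acid receptor 1 assay, the saturated chain carbon bound to an aromatic carbon and a saturated chain carbon takes ethoxy in place of methyl with no change beyond the scatter, giving a 1.4-fold higher number from compound 3 to compound 4 (0.15 log units; within the scatter). The 2-carboxy-1-ethoxyethyl chain of compound 4 also stands clear of the other two side chains, with an 8.6-fold lower number from compound 2 to compound 4 (0.93 log units; beyond the scatter) and a 4.6-fold lower number from compound 1 to compound 4 (0.67 log units; beyond the scatter), so the advantage first seen for compound 3 survives this substitution. The same change does register in a physicochemical assay for lipophilicity, at pH 7.4 (a higher number here means a more lipophilic compound, a lower number a more polar compound), where compound 3 gives 3.3 and compound 4 gives 2.8, so that compound 4 is the more polar of the pair while its number in the Free fatty acid receptor 1 assay stays within the scatter of that of compound 3: the measured distribution coefficient of compound 3, 3.3, and of compound 4, 2.8, a number 0.50 log units lower (beyond the scatter)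

With a single alkoxy group at this position, the compounds shown cannot separate the part played by the ether oxygen from that of the two added carbons. Going by these compounds, whether a hydroxyl group or a longer propoxy chain on this carbon would hold the number in the Free fatty acid receptor 1 assay while shifting the distribution coefficient further remains open.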